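This account rests on a few compounds, and the source may have more. Where it says the series, first, only, none or still open, it means among the compounds named here.

Measured in a functional assay on MOLT-4F cells (Homo sapiens) for antiproliferative activity; on this read-out lower numbers stand for stronger inhibition of growth and higher numbers for weaker inhibition of growth:
- compound 1 `COCCCCCCCCCCCCCCC/C=C1\CC(CO)(COC(=O)C(C)(C)C)OC1=O`: 0.498 ug/mL
- compound 2 `COC(=O)CCCCCCCCCCCCCC/C=C1\CC(CO)(COC(=O)C(C)(C)C)OC1=O`: > 10 ug/mL (a limit)
- compound 3 `CC(C)(C)C(=O)OCC1(CO)C/C(=C\CCCCCCCCCCCCCCC=O)C(=O)O1`: > 10 ug/mL (a limit)

Compound 3 stands at the limit of > 10 ug/mL in this assay, at which 2 of the 3 values shown sit. Compound 4 `CC(=O)OCCCCCCCCCCCCCCC/C=C1\CC(CO)(COC(=O)C(C)(C)C)OC1=O` differs from it by acetoxymethyl in place of formyl on a saturated chain carbon, ten or more bonds along the chain from a double-bonded chain carbon, with acetoxymethyl in place of formyl on a saturated chain carbon. Among the measured compounds shown here, two measured steps bear on this: an at least 20-fold higher number from compound 1 to compound 2 (1.30 log units; beyond the scatter) and an at least 20-fold higher number from compound 1 to compound 3 (1.30 log units; beyond the scatter). Both are large, and only compound 1 has a measured number. Acetoxymethyl matches none of the three groups, so a partial return towards compound 1 is expected in this assay, though a result at the limit remains possible. The expected step is an at least 4.0-fold lower number from compound 3 to compound 4 (0.60 log units; beyond the scatter). Compound 4 is estimated at 2.5 ug/mL (range 0.6 ug/mL to 10 ug/mL).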

Compound 4, concentration for 50% growth inhibition: 1.55 ug/mL
Beside the measured number, compound 4's estimate is 1.6-fold (0.21 log units) above it; the range from low to high includes it.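

In this assay, a carbonyl group at this chain end does not by itself bring the loss of growth inhibition, since acetoxymethyl gives an at least 6.4-fold lower number from compound 3 to compound 4 (0.80 log units; beyond the scatter) and an at least 6.4-fold lower number from compound 2 to compound 4 (0.80 log units; beyond the scatter). Acetoxymethyl still does not fully match the methoxymethyl end, with a 3.1-fold higher number from compound 1 to compound 4 (0.49 log units; beyond the scatter). The first two steps are open-ended, as each starts from a limit and not a number: the limit of > 10 ug/mL in this assay, at which 2 of the 4 values shown sit.

Still open, on these data alone, is whether a free hydroxyl, a carboxylic acid or an amine at this chain end would stay close to compound 1 or fall to the limit. Also open, as far as these compounds go, is how a longer chain carrying the acetoxy end would behave.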